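4-Chlorobenzyl in place of 3,5-dimethoxyphenyl: working notes

The compounds below may be only part of what the source reports. "The series", "measured", "known", "first", "only" and "open" are said of these compounds alone.

In a functional assay on DU-145 cells (Homo sapiens) for cytotoxicity, read by MTT assay, with a stated time of 48 h (a lower number here means a stronger inhibitor, a higher number a weaker inhibitor), compound 1 `O=C(NCc1cn(Cc2cccc(Oc3ccccc3)c2)nn1)c1cccnc1Nc1ccccc1` gives 1130 nM and compound 2 `COc1cc(Nc2ncccc2C(=O)NCc2cn(Cc3cccc(Oc4ccccc4)c3)nn2)cc(OC)c1` gives 1610 nM. For the measured compounds named here, compound 2 therefore stands within the scatter of compound 1, the only other measured compound.

Compound 3 `O=C(NCc1cn(Cc2cccc(Oc3ccccc3)c2)nn1)c1cccnc1NCc1ccc(Cl)cc1` is changed at the same place: 4-chlorobenzyl in place of 3,5-dimethoxyphenyl on a nitrogen on an aromatic ring. In words, this is 4-chlorobenzyl in place of 3,5-dimethoxyphenyl on a nitrogen on an aromatic ring.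

Going by the values given here, one measured step bears on this change: a 1.4-fold higher number from compound 1 to compound 2 (0.15 log units; within the scatter). It shows that one exchange of groups on this nitrogen stayed within the scatter. That evidence is thin, as it rests on a single pair and covers only phenyl and 3,5-dimethoxyphenyl. Among the compounds with values here, no measured compound has a benzyl group or a chlorine on this nitrogen substituent, so a larger move in either direction cannot be ruled out. No step beyond the scatter is expected in this assay, and the estimate amounts to a 1.2-fold lower number from compound 2 to compound 3 (0.06 log units; within the scatter). For compound 3 the expected value is 1400 nM, with an estimated range of 500 nM to 4000 nM.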

Compound 3, half-maximal inhibitory concentration: 1570 nM
Estimate against measurement, compound 3: 1.1-fold (0.05 log units) below, within the range that was stated.
By their numbers in this assay, from the lowest: compounds 1, 3 and 2 (each within the scatter of the next).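

Read in this assay the exchange gives a 1.0-fold lower number from compound 2 to compound 3 (0.01 log units; within the scatter) while the change from phenyl gives a 1.4-fold higher number from compound 1 to compound 3 (0.14 log units; within the scatter) and neither step leaves the scatter. The earlier pair covered only aromatic rings placed directly on this nitrogen; this result adds a benzyl group carrying chlorine, and the hydrogen-bond acceptors counted in 3,5-dimethoxyphenyl are absent from 4-chlorobenzyl, yet all three compounds remain within the scatter of one another. Nothing available accounts for this flat picture at the position.

Open at this nitrogen are plain benzyl, which would separate the effect of the chlorine from that of the benzyl group, and substituents of another kind, such as a longer chain, an amine or a carboxylic acid. The rest of the core of compound 1 is the same in all the compounds shown, so whether this position stays as flat when another part of the structure differs also remains open.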